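The compounds below may be only part of what the source reports. "The series", "measured", "known", "first", "only" and "open" are said of these compounds alone.

Working notes on a shared core. Of the two numbers measured in a functional assay on thoracic aorta (Rattus norvegicus, strain Wistar), with a stated time of 15 min (a lower number here means that less compound is needed, a higher number that more compound is needed for the effect), compound 1 `COc1ccc(Br)cc1C(C)NC(=O)NS(=O)(=O)c1ccc(Cl)cc1` gives 80900 nM. Compound 3 `CC(C)Oc1ccc(Br)cc1C(C)NC(=O)NS(=O)(=O)c1ccc(Cl)cc1` gives 122000 nM, a step of a 1.5-fold higher number from compound 1 to compound 3 (0.18 log units; within the scatter) that leaves the two level. Compound 2 `COc1ccc(Cl)cc1C(C)NC(=O)NS(=O)(=O)c1ccc(Cl)cc1` reaches only the assay limit > 300000 nM. The step of an at least 3.7-fold higher number from compound 1 to compound 2 (0.56 log units; beyond the scatter) is the one move beyond the scatter, read against (the limit of > 300000 nM in this assay, at which 1 of the 3 values shown sits).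

Compound 4 `COc1ccc(Br)cc1C(C)NC(=O)NS(=O)(=O)c1ccc(C)cc1` is not yet measured and differs from compound 1 by methyl in place of chloro on an aromatic carbon. Neither measured step touches this ring, so none bears on it directly; the halogen swap on the other ring gave a loss, the alkoxy change none. For compound 4 a small loss or none beyond the scatter is expected, a 1.5-fold higher number from compound 1 to compound 4 (0.17 log units; within the scatter). Compound 4 is therefore estimated at 120000 nM, between 50000 nM and 300000 nM in this assay.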

Compound 4, half-maximal effective concentration: > 300000 nM
Compound 4: a limit, no number (the forecaster's own chance of this, stated with the estimate: 25%); at least 2.5-fold (0.39 log units) between middle value and limit.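

The change from 4-chlorophenyl to 4-methylphenyl gives an at least 3.7-fold higher number from compound 1 to compound 4 (0.56 log units; beyond the scatter), so in this assay the group on this ring also matters, and not only the halogen on the other ring. Chloro is not interchangeable with methyl here, although the two count the same in heavy atoms, donors and acceptors. Compound 4 gives a limit and not a number, so the step is only a minimum: the limit of > 300000 nM in this assay, at which 2 of the 4 values shown sit.

On these data alone, what a bromo, a methoxy or an amine at this position would give stays open. As far as these compounds go, the true size of the loss from chloro to methyl also stays open.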